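The compounds below may be only part of what the source reports. "The series", "measured", "known", "first", "only" and "open" are said of these compounds alone.

The measured compounds:

Compound 1, `CCOC(=O)C1=Cc2ccccc2OC1(OCc1cc(-c2ccc(F)cc2F)no1)C(F)(F)F`, which in a functional assay on DU-145 cells (Homo sapiens) for inhibition, read by MTT assay, with a stated time of 24 h (on this read-out higher numbers stand for weaker inhibition and lower numbers for stronger inhibition), gives only a limit, > 150000 nM.
Compound 2, `CCOC(=O)C1=Cc2ccccc2OC1(OCc1cc(-c2ccc3ccccc3c2)no1)C(F)(F)F`, which in this assay gives 71800 nM.
Compound 3, `O=C(O)C1=Cc2ccccc2OC1(OCc1cc(-c2ccc3ccccc3c2)no1)C(F)(F)F`, which in this assay gives 141000 nM.

Compound 2 and compound 3 share their aromatic side group and differ only in the core, where (hydrogen in place of ethyl on an oxygen next to a carbonyl group); this gave a 2.0-fold higher number from compound 2 to compound 3 (0.29 log units; within the scatter), so the two numbers are not told apart. Compound 1 keeps the ester core of compound 2 but carries the smaller aromatic group: 2,4-difluorophenyl in place of naphthalen-2-yl on an aromatic carbon. That change brought an at least 2.0-fold higher number from compound 2 to compound 1 (0.31 log units; beyond the scatter). For compound 1 the value is only a limit, (the limit of > 150000 nM in this assay, at which 1 of the 3 values shown sits).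

Compound 4, `O=C(O)C1=Cc2ccccc2OC1(OCc1cc(-c2ccc(F)cc2F)no1)C(F)(F)F`, has not yet been measured. Going by the values given here, it differs from compound 3 in that (2,4-difluorophenyl in place of naphthalen-2-yl on an aromatic carbon), the same change as the one made from compound 2 to compound 1, at a place described in the same words. Compound 3 already sits at the higher of the two numbered values, and the earlier step of this change ran into the limit, so compound 4 is expected to be weaker still: the step is estimated as a 2.1-fold higher number from compound 3 to compound 4 (0.33 log units; beyond the scatter). Compound 4 is therefore estimated at 300000 nM, expected between 150000 nM and 1000000 nM, and most likely reported only as a limit.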

Compound 4, half-maximal inhibitory concentration: > 150000 nM
Compound 4 gave a limit, no number; the forecaster's own chance of this, stated with the estimate: 80%; the middle value is on the limit's open side.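

In this assay compound 4 gives only a limit, > 150000 nM. Placing 2,4-difluorophenyl in place of naphthalen-2-yl on the core of compound 3 therefore yields an at least 1.0-fold higher number from compound 3 to compound 4 (0.02 log units; that floor lies within the scatter), which is a floor and not a measured size, and the comparison with the same change on the other core reads: the same change on two cores in this assay, an at least 2.0-fold higher number (0.31 log units; beyond the scatter) from compound 2 to compound 1 and an at least 1.0-fold higher number (0.02 log units; that floor lies within the scatter) from compound 3 to compound 4; the limit leaves it open whether they differ. On both cores the compound carrying 2,4-difluorophenyl ends at a limit, and nothing points to stronger inhibition after the change, but this does not show that the change has the same size on the two cores, and the step between compound 1 and compound 4 cannot be read, as both values are limits: the limit of > 150000 nM in this assay, at which 2 of the 4 values shown sit.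

The compounds shown leave open how far past the limit compound 1 and compound 4 lie, and so whether the choice between the ethyl ester and the carboxylic acid matters at all once 2,4-difluorophenyl is in place. They also leave open whether a primary amide or a hydroxymethyl group on the core, or an unsubstituted phenyl on the same aromatic carbon, would give a measurable number in this assay.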